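Hydroxyl for a phenyl: a step in retinal dehydrogenase inhibition

The compounds below may be only part of what the source reports. "The series", "measured", "known", "first", "only" and "open" are said of these compounds alone.

Compound 1: `CC(Sc1nc2c(cnn2C)c(=O)n1-c1ccccc1)c1ccccn1`, 63 nM
Compound 2: `CCC(Sc1nc2c(cnn2C)c(=O)n1-c1ccccc1)c1ccccc1`, 179 nM

Of the two compounds measured in an assay on isolated protein for inhibition of retinal dehydrogenase 2 (Homo sapiens) (a lower number here means a stronger inhibitor, a higher number a weaker inhibitor), compound 2 gives the highest number, 179 nM. For the measured compounds named here, its nearest neighbour is compound 1, at 63 nM, and the only measured step runs between them: a 2.8-fold higher number from compound 1 to compound 2 (0.45 log units; beyond the scatter). That step swaps a 1-(pyridin-2-yl)ethyl for a 1-phenylpropyl on the sulfur, so it changes both the aromatic ring and the chain at once.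

Compound 3, `CC(Sc1nc2c(cnn2C)c(=O)n1-c1ccccc1)c1cccc(O)c1`, has not yet been measured. Its change from compound 2 is a group of 9 heavy atoms (8 carbon, 1 oxygen; one six-membered aromatic ring of carbon only) in place of a group of 9 heavy atoms (9 carbon; one six-membered aromatic ring of carbon only), on a sulfur. The step from compound 1 to compound 2 bears on it only loosely: it too altered the group on the sulfur, and it was modest in size. Nothing measured isolates the effect of a hydroxyl on the aromatic ring. A step of similar modest size is therefore expected, in either direction but more likely toward a lower number, given that the chain in compound 3 resembles that of compound 1 with its 63 nM. For compound 3 the estimate is 110 nM, within 40 nM to 300 nM, a step of a 1.6-fold lower number from compound 2 to compound 3 (0.21 log units; within the scatter).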

Compound 3, half-maximal inhibitory concentration: 100 nM
Compound 3: the middle estimate sits 1.1-fold (0.04 log units) above what was measured, and the stated range covers the measured number.
By their numbers in this assay, from the lowest: compounds 1, 3 and 2 (each within the scatter of the next, the first and the last beyond it).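

In this assay, the step of a 1.8-fold lower number from compound 2 to compound 3 (0.25 log units; within the scatter) lies within the scatter, so replacing 1-phenylpropyl with a group of the same heavy-atom count that carries one hydrogen-bond donor and one acceptor gives no change that can be told apart from repeat measurement. The step with 3-hydroxyphenyl in place of pyridin-2-yl on a saturated chain carbon, a 1.6-fold higher number from compound 1 to compound 3 (0.20 log units; within the scatter), also lies within the scatter, so the compounds shown do not separate these two rings, and compound 3 stands within the scatter of both earlier compounds even though those two lie beyond it from each other. Nothing available explains these numbers.

From the compounds shown here alone, it remains open how much of the step to compound 3 belongs to the hydroxyl and how much to the shorter chain, as the two change together in that step. Also open, going by these compounds, is whether an amine or a methoxy group in place of the hydroxyl, or a longer chain on the saturated carbon, would give a number in the same range.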